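Shrinking the amide ring in a phthalazinone series

A few compounds are considered here, and "the series" means these few. Any claim that something is new, unique, unknown or untested is made for them only; others in the source may bear on it.

Compound 3 `Cn1cc(-c2nn(Cc3ccc(C(=O)NC4CCCC4)cc3)c(=O)c3ccccc23)cn1` is measured in a functional assay on LoVo cells (Homo sapiens) for antiproliferative activity, read by MTT assay, with a stated time of 72 h (a lower number here means a stronger inhibitor, a higher number a weaker inhibitor), and gives 23700 nM. Among the numbers shown it stands lowest; the nearest is compound 1 `CN1CCC(NC(=O)c2ccc(Cn3nc(-c4cnn(C)c4)c4ccccc4c3=O)cc2)CC1`, which in this assay gives 83300 nM, so the change a 3.5-fold lower number from compound 1 to compound 3 (0.55 log units; beyond the scatter) is the only step bearing on the amide substituent. Compound 2 `Cc1noc(C)c1-c1nn(Cc2ccc(C(=O)NC3CC3)cc2)c(=O)c2ccccc12` carries a different group on the shared core and in this assay reaches only a limit, > 100000 nM; this is the limit of > 100000 nM in this assay, at which 1 of the 3 values shown sits, not a number, and it is the sole appearance of the cyclopropyl amide among the measured values.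

Compound 4 `Cn1cc(-c2nn(Cc3ccc(C(=O)NC4CC4)cc3)c(=O)c3ccccc23)cn1` is the partner of compound 3 in which (cyclopropyl in place of cyclopentyl on an amide-type nitrogen). Going by the values given here, no measured step separates these two ring sizes on an otherwise identical core. Among the compounds with values here, the one amide step known, from compound 1 to compound 3, went toward the larger ring and was modest; the cyclopropyl amide appears only in compound 2, where it sits at the limit. From this the account expects compound 4 to be somewhat weaker than compound 3, with a 2.1-fold higher number from compound 3 to compound 4 (0.32 log units; beyond the scatter) as the estimated step, and an expected value in this assay for compound 4 of 50000 nM within 15000 nM to 160000 nM.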

Compound 4, half-maximal inhibitory concentration: 48200 nM
Estimate against measurement, compound 4: 1.0-fold (0.02 log units) above, and the stated range covers the measured number.
By their numbers in this assay, from the lowest: compound 3; then compounds 4 and 1 (each within the scatter of the next). At a limit, above all of these: compound 2.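

In this assay, cyclopropyl and cyclopentyl on the amide-type nitrogen can now be compared directly on an otherwise identical core, and the smaller ring gives a modest loss (a 2.0-fold higher number from compound 3 to compound 4 (0.31 log units; beyond the scatter)). Cyclopropyl and 1-methylpiperidin-4-yl, however, cannot be told apart (a 1.7-fold lower number from compound 1 to compound 4 (0.24 log units; within the scatter)), so among these three amide substituents only cyclopentyl stands clear of the other two, and activity does not simply follow ring size. Compound 4 also makes the group on the aromatic carbon readable for the first time, with 1-methyl-1H-pyrazol-4-yl in place of 3,5-dimethyl-1,2-oxazol-4-yl (an at least 2.0-fold lower number from compound 2 to compound 4 (0.31 log units; beyond the scatter)), although this step is open-ended, as the value of compound 2 is a limit and not a number: the limit of > 100000 nM in this assay, at which 1 of the 4 values shown sits.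

The compounds shown leave open whether cyclobutyl or cyclohexyl on the amide-type nitrogen would extend the gain seen with cyclopentyl, and whether an open chain such as isopropyl would serve as well as a ring. They also leave open whether 3,5-dimethyl-1,2-oxazol-4-yl paired with the cyclopentyl amide would give a measurable number, which would show how far the two positions act independently.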